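Shortening the Chain Again: What to Expect of Compound 3

A few compounds are considered here, and "the series" means these few. Any claim that something is new, unique, unknown or untested is made for them only; others in the source may bear on it.

Compound 1 `Nc1ncnc2c1c(-c1cnc3[nH]ccc3c1)nn2CCCCCCCCCC(=O)NO`: 10100 nM
Compound 2 `Nc1ncnc2c1c(-c1cnc3[nH]ccc3c1)nn2CCCCCCC(=O)NO`: 37700 nM

For the measured compounds named here, in a functional assay on MDA-MB-231 cells (Homo sapiens) for inhibition, read by MTT assay, with a stated time of 72 h (a lower number here means a stronger inhibitor, a higher number a weaker inhibitor), compound 2 stands at the higher of the two numbers measured so far, which makes it the weaker inhibitor of this pair. The next compound, compound 3 `Nc1ncnc2c1c(-c1cnc3[nH]ccc3c1)nn2CCCC(=O)NO`, has hydroxycarbamoyl in place of 3-(hydroxycarbamoyl)propyl on a saturated chain carbon, three bonds along the chain from an aromatic nitrogen. Going by the values given here, only one measured step bears on this change. The same replacement, made six bonds along the chain from an aromatic nitrogen, gave a 3.7-fold higher number from compound 1 to compound 2 (0.57 log units; beyond the scatter), a modest step beyond the scatter. A single step establishes no pattern, and the data do not show whether it repeats at the new place. Even so, a step of similar size toward a higher number is the most reasonable expectation in this assay. The expected step is a 2.7-fold higher number from compound 2 to compound 3 (0.42 log units; beyond the scatter). Compound 3 is estimated at 100000 nM, with an expected range of 40000 nM to 300000 nM.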

Compound 3, half-maximal inhibitory concentration: > 150000 nM
Compound 3 ended at the assay's limit (the forecaster's own chance of this, stated with the estimate: 35%); middle value at least 1.5-fold (0.17 log units) away from the limit.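

For compound 3 the reading in this assay is a limit and not a number: the limit of > 150000 nM in this assay, at which 1 of the 3 values shown sits.

Even so, the replacement three bonds along the chain from an aromatic nitrogen gives an at least 3.9-fold higher number from compound 2 to compound 3 (0.59 log units; beyond the scatter), so the direction seen six bonds along the chain from an aromatic nitrogen now appears at a second place. Across the three compounds shown, the number rises with each shortening of the chain, no compound goes against this order, and the whole change, hydroxycarbamoyl in place of 6-(hydroxycarbamoyl)hexyl, gives an at least 14-fold higher number from compound 1 to compound 3 (1.17 log units; beyond the scatter), a large step of a size the earlier pair did not reach.

Going by these compounds, how far compound 3 lies past its limit remains unknown, so the second step cannot be compared in size with the first. The compounds shown also leave open whether a longer chain than that of compound 1 would lower the number further, and whether a carboxylic acid in place of the hydroxycarbamoyl end would retain the inhibition that compound 1 shows at 10100 nM.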